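The compounds below may be only part of what the source reports. "The series", "measured", "known", "first", "only" and "open" are said of these compounds alone.

Measured so far in a functional assay on MDA-MB-435 cells (Homo sapiens) for inhibition, read by sulforhodamine B assay, with a stated time of 48 h, tested at 10 uM; on this read-out lower numbers stand for a stronger effect and higher numbers for a weaker effect at the one concentration tested:
- compound 1 `COc1cc(Cl)cc(-c2nn(-c3cccc(NC(=O)c4ccc(Cl)c(Cl)c4)c3)cc2-c2ccncc2)c1`: 80.8%
- compound 2 `O=C(Nc1cccc(-n2cc(-c3ccncc3)c(-c3cc(O)cc(Cl)c3)n2)c1)Nc1ccc(Cl)c(Cl)c1`: -33.3%
- compound 3 `COc1cc(Cl)cc(-c2nn(-c3cccc(NC(=O)Nc4ccc(Cl)c(C(F)(F)F)c4)c3)cc2-c2ccncc2)c1`: -16.8%

Compound 3 stands second highest of the three numbers. Its nearest neighbour is compound 2, which reads lower, beyond the scatter; compound 1 is far above it, and the step of a number 97.6 percentage points lower from compound 1 to compound 3 (beyond the scatter) is large. That step, however, carries two changes at once, the amide-to-urea change and the exchange of the aryl substituent, so it cannot be split into parts.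

Compound 4 `COc1cc(Cl)cc(-c2nn(-c3cccc(NC(=O)Nc4ccc(Cl)c(Cl)c4)c3)cc2-c2ccncc2)c1` is the next member. Its difference from compound 3 is chloro in place of trifluoromethyl on an aromatic carbon. Going by the values given here, no measured pair shows this exchange on its own. Among the compounds with values here, the only compound sharing the urea and the 3,4-dichlorophenyl group is compound 2, which differs from compound 4 elsewhere, by hydroxy in place of methoxy; it reads lower than compound 3, beyond the scatter, and both lie far below compound 1. Taken together, compound 2 and compound 3 suggest compound 4 will read in the same low region, and any step a number 5.2 percentage points lower from compound 3 to compound 4 (within the scatter) is expected to stay within or only modestly beyond the scatter, if anything toward lower numbers. For compound 4 the estimate in this assay is therefore -22%, with a range from -48% to 6%.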

Compound 4, a percentage reported as activity, at one concentration (the size of the read-out at that concentration, not a potency): 0.46%
Beside the measured number, compound 4's estimate is 22.5 percentage points below it, and the stated range covers the measured number.
By their numbers in this assay, from the lowest: compound 2; then compound 3; then compound 4; then compound 1.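

In this assay the exchange of trifluoromethyl for chloro on this aromatic carbon, ortho to a chloro group, now reads on its own with the urea held fixed, and it gives a number 17.3 percentage points higher from compound 3 to compound 4 (beyond the scatter) as a modest step toward a weaker effect. Going by these compounds alone, with 3,4-dichlorophenyl held fixed, the amide-to-urea change also reads on its own for the first time, and a number 80.3 percentage points lower from compound 1 to compound 4 (beyond the scatter) shows that this change alone gives a large step toward a stronger effect, larger than the aryl exchange. Within the data shown here, the aromatic oxygen substituent, which the earlier compounds did not separate from the rest, also counts, since methoxy in place of hydroxy gives a number 33.8 percentage points higher from compound 2 to compound 4 (beyond the scatter) as a large step toward a weaker effect.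

Still open, going by these compounds, is how an amine or a carboxylic acid on this aromatic carbon, or an ethoxy group in place of the methoxy, would read on this urea series. Nothing available here offers an explanation for any of these steps.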